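This account rests on a few compounds, and the source may have more. Where it says the series, first, only, none or still open, it means among the compounds named here.

The measured compounds:
Compound 1 `O=C(Nc1ccc(S(=O)(=O)Nc2ccccc2)cc1)c1cc(F)c(Cl)cc1F` gives 141 nM in a functional assay on HEK293 cells for agonist activity at probable G-protein coupled receptor 27 (Homo sapiens), read by a luciferase reporter and beta-arrestin recruitment, with a stated time of 10 min; a lower number here means that less compound is needed, a higher number that more compound is needed for the effect.
Compound 2 `COc1ccc(NS(=O)(=O)c2ccc(NC(=O)c3ccc(Cl)cc3Cl)cc2)cc1` gives > 100000 nM in this assay, which is a limit of the assay and not a number.

Among the results shown, compound 1 therefore holds the only actual number; the other entry sits at the limit of > 100000 nM in this assay, at which 1 of the 2 values shown sits, so compound 1 cannot be ranked against anything measured. Compound 3 `O=C(Nc1ccc(S(=O)(=O)Nc2ccccc2)cc1)c1ccc(Br)cc1F` has not yet been tested. It differs from compound 1 in a single place: 4-bromo-2-fluorophenyl in place of 4-chloro-2,5-difluorophenyl on a carbonyl carbon. Among the measured compounds shown here, no step between two measured compounds is available, so there is no earlier example of this kind of swap from which to read off its size or direction. Chlorine giving way to bromine, while one fluorine is removed, leaves the rest of compound 1 untouched, and without a comparable measured pair the expectation is a change no larger than the usual scatter, in no particular direction. Compound 3 is thus expected to land near 200 nM, plausibly anywhere from 50 nM to 1000 nM. The step from compound 1 implied by this estimate is a 1.4-fold higher number from compound 1 to compound 3 (0.15 log units; within the scatter), small and uncertain in sign.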

Compound 3, half-maximal effective concentration: 479 nM
Compound 3: middle estimate off by 2.4-fold (0.38 log units), on the low side; the measured number falls inside the stated range.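

In this assay, among the compounds shown here, this result gives the first measured step at the position on the carbonyl carbon: a 3.4-fold higher number from compound 1 to compound 3 (0.53 log units; beyond the scatter). The earlier compounds shown here offered no such step, and this one shows that 4-bromo-2-fluorophenyl in place of 4-chloro-2,5-difluorophenyl has a modest but real effect, with compound 3 still giving an actual number rather than a limit. The swap makes two edits at once, exchanging chlorine for bromine and removing one fluorine, and nothing measured here gives a reason for the size or direction of the step.

Which of those two edits carries the step remains open, and telling them apart would take a compound that keeps the rest of compound 1 and differs from it by only one of the two edits. Also open, going by these compounds, is how this position responds to something other than halogens, such as an amine or a carboxylic acid on the phenyl ring attached to the carbonyl carbon.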